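From Free Acid to Aryl Ester on the Shared Core

A few compounds are considered here, and "the series" means these few. Any claim that something is new, unique, unknown or untested is made for them only; others in the source may bear on it.

Compound 1 `CC(C)(C)OC(=O)/C=C1/C(=O)Nc2ccccc21`: 2450 nM
Compound 2 `CC(C)(C)OC(=O)/C=C1/C(=O)N(Cc2ccccc2)c2ccccc21`: 13800 nM
Compound 3 `CN1C(=O)/C(=C/C(=O)O)c2ccccc21`: 83700 nM

All three were tested in a functional assay on HL-60 cells (Homo sapiens) for cytotoxicity, read by CCK-8 assay, with a stated time of 72 h; on this read-out higher numbers stand for weaker inhibition and lower numbers for stronger inhibition. Among them, compound 3 gives the highest number, that is the weakest inhibition; compound 2 stands nearest to it and compound 1 furthest from it, both gaps lying beyond the scatter. The two compounds with the lower numbers both carry an ester rather than the free acid of compound 3.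

Compound 4 `CN1C(=O)/C(=C/C(=O)Oc2ccc(Cl)cc2)c2ccccc21` differs from compound 3 in one place: 4-chlorophenyl in place of hydrogen on an oxygen next to a carbonyl group. Going by the values given here, the only measured step, a 5.6-fold higher number from compound 1 to compound 2 (0.75 log units; beyond the scatter), concerns a different site, the ring nitrogen, so it does not bear directly on this change. Among the compounds with values here, no measured pair isolates the acid-to-ester exchange, since compound 3 differs from compound 1 and from compound 2 in two places at once. What the numbers do show is that the two esters give lower numbers than the acid. On that basis compound 4 is expected to give a lower number than compound 3, with the step of a 9.3-fold lower number from compound 3 to compound 4 (0.97 log units; beyond the scatter) as the estimate, though the uncertainty is wide. The estimated value for compound 4 in this assay is 9000 nM, within a range from 2000 nM to 45000 nM.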

Compound 4, half-maximal inhibitory concentration: 12200 nM
For compound 4 the middle estimate is 1.4-fold (0.13 log units) below the measured one; low and high end bracket the measured number.
By their numbers in this assay, from the lowest: compound 1; then compounds 4 and 2 (each within the scatter of the next); then compound 3.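

In this assay the exchange of hydrogen for 4-chlorophenyl, on an oxygen next to a carbonyl group, gives a 6.9-fold lower number from compound 3 to compound 4 (0.84 log units; beyond the scatter) and turns the free acid into an aryl ester. This is the first pair shown that differs only at this position, whereas the earlier comparisons of the acid with the esters changed two places at once and could only hint at the effect of the exchange. It shows that the acid hydrogen is not needed for activity in these cells, and that a sizeable aromatic group can sit on this oxygen while the number still falls beyond the scatter, although no measurement shown here explains the drop.

One pair cannot tell whether the lower number depends on the 4-chlorophenyl group in particular or would also come with a plain phenyl ring, a 4-methoxyphenyl ring or a small ethyl ester at the same oxygen. On these data alone, it also remains open how this position would respond to an amide in place of the ester, or to a longer chain ending in an amine.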